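From 4-cyanophenyl to methyl on the shared core

This account rests on a few compounds, and the source may have more. Where it says the series, first, only, none or still open, it means among the compounds named here.

In an ADME assay on L6 cells (Rattus norvegicus) for cytotoxicity, read by fluorescence and resazurin assay, with a stated time of 72 h (a higher number here means that more compound is needed for the effect, a lower number that less compound is needed), compound 1 `O=c1nc(-c2ccccc2)c2cc(-c3ccccc3)ccc2[nH]1` reads > 50000 nM, which is a limit of the assay. Compound 2 `O=c1nc(-c2ccccc2)c2cc(-c3ccc(F)cc3)ccc2[nH]1` gives 50000 nM. Compound 3 `N#Cc1ccc(-c2ccc3[nH]c(=O)nc(-c4ccccc4)c3c2)cc1` stands at > 50000 nM, also a limit and not a number. Compound 4 `Cc1ccc2[nH]c(=O)nc(-c3ccccc3)c2c1` follows from compound 3 by methyl in place of 4-cyanophenyl on an aromatic carbon, with methyl in place of 4-cyanophenyl on an aromatic carbon.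

Among the compounds with values here, three measured steps bear on this only loosely: a number no higher from compound 1 to compound 2 (the limit leaves the size open), a step that the two limits leave unreadable from compound 1 to compound 3 and a number no lower from compound 2 to compound 3 (the limit leaves the size open). From the compounds shown here alone, their sizes stay open, and none of them removes the 4-cyanophenyl group. The main anchor is therefore (the limit of > 50000 nM in this assay, at which 2 of the 3 values shown sit), together with compound 2 at 50000 nM. In this assay, a small move to lower numbers is expected, or none beyond the scatter. The expected change is an at least 1.2-fold lower number from compound 3 to compound 4 (0.09 log units; that floor lies within the scatter). Compound 4 is estimated at 40000 nM, with an expected range of 15000 nM to 60000 nM.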

Compound 4, half-maximal effective concentration: > 50000 nM
Compound 4: a limit, no number (the forecaster's own chance of this, stated with the estimate: 55%); middle value at least 1.2-fold (0.09 log units) away from the limit.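

In this assay compound 4 reads > 50000 nM, which is a limit of the assay. Within the data shown here, the 4-cyanophenyl group, with its six-membered aromatic ring of carbon only and its nitrile, can therefore give way to methyl without a readable number appearing, so the reading at this position does not depend on an aromatic substituent, and only compound 2 stands apart from the shared limit: the limit of > 50000 nM in this assay, at which 3 of the 4 values shown sit. Measured against the one compound with a number, the change gives a number no lower from compound 2 to compound 4 (the limit leaves the size open), while the steps from compound 1 and compound 3 to compound 4 cannot be read, as both ends are limits.

From the compounds shown here alone, whether an amine, a carboxylic acid or a longer chain at this position would bring a readable number stays open. Going by these compounds, how far compound 1, compound 3 and compound 4 lie from one another also stays open.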